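Sulfonyl in place of carbonyl on the ring nitrogen

A few compounds are considered here, and "the series" means these few. Any claim that something is new, unique, unknown or untested is made for them only; others in the source may bear on it.

Measured so far:
Compound 1 `O=C(Nc1cccc(/C=C/C(=O)c2nc3ccccc3[nH]2)c1)c1cccc(Cl)c1` — 1120 nM
Compound 2 `O=C(Nc1cccc(/C=C/C(=O)c2nc3ccccc3[nH]2)c1)c1cc(Cl)cc(Cl)c1` — 1650 nM

Among the measured compounds shown here, in a functional assay on HCT-116 cells (Homo sapiens) for antiproliferative activity, read by MTT assay, with a stated time of 48 h (on this read-out higher numbers stand for weaker inhibition and lower numbers for stronger inhibition), compound 1 gives 1120 nM, the lowest of the two numbers, with compound 2 nearest; the one measured step is a 1.5-fold higher number from compound 1 to compound 2 (0.17 log units; within the scatter), a change of chloro for hydrogen that says nothing about the linker. Compound 3 `O=C(/C=C/c1cccc(NS(=O)(=O)c2cccc(Cl)c2)c1)c1nc2ccccc2[nH]1` differs from compound 1 by (3-chlorophenyl)sulfonyl in place of (3-chlorophenyl)carbonyl on a nitrogen on an aromatic ring. For the measured compounds named here, no measured step bears on that exchange, so the expectation is a step no larger than the scatter, a 1.3-fold higher number from compound 1 to compound 3 (0.13 log units; within the scatter), with wide uncertainty. Compound 3 is therefore estimated at 1500 nM, in the range 450 nM to 5000 nM.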

Compound 3, half-maximal inhibitory concentration: 737 nM
Estimate against measurement, compound 3: 2.0-fold (0.31 log units) above; low and high end bracket the measured number.
By their numbers in this assay, from the lowest: compounds 3, 1 and 2 (each within the scatter of the next, the first and the last beyond it).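

In this assay, the nitrogen on the aromatic ring carries (3-chlorophenyl)sulfonyl as readily as (3-chlorophenyl)carbonyl: a 1.5-fold lower number from compound 1 to compound 3 (0.18 log units; within the scatter) shows that this exchange does not separate the two compounds beyond the scatter. The step of a 2.2-fold lower number from compound 2 to compound 3 (0.35 log units; beyond the scatter) does lie beyond it, but it combines the exchange of carbonyl for sulfonyl with the loss of a chloro, so neither change can be credited alone. Nothing available accounts for either step.

Still open, on these data alone, is how (3,5-dichlorophenyl)sulfonyl would compare with compound 2 and compound 3, which would separate those two changes. Also open, as far as these compounds go, is whether this nitrogen accepts a sulfonyl without an aromatic ring, such as methylsulfonyl.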